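Compound 3: methyl in place of trifluoromethyl

The compounds below may be only part of what the source reports. "The series", "measured", "known", "first", "only" and "open" are said of these compounds alone.

The series shares the core of compound 1 `COc1ccc(Nc2ccnc(Nc3ccc(NS(=O)(=O)c4ccc(OC)cc4)cc3)n2)cc1`, which in a functional assay on MDA-MB-231 cells (Homo sapiens) for antiproliferative activity, read by MTT assay (a lower number here means a stronger inhibitor, a higher number a weaker inhibitor), gives 6870 nM. Within the data shown here, compound 2 `COc1ccc(Nc2ccnc(Nc3ccc(NS(=O)(=O)c4ccc(C(F)(F)F)cc4)cc3)n2)cc1`, carrying trifluoromethyl in place of methoxy on an aromatic carbon, gives 27200 nM in this assay; this is the highest of the two numbers measured so far, the nearest being compound 1, with a 4.0-fold higher number from compound 1 to compound 2 (0.60 log units; beyond the scatter).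

Compound 3 `COc1ccc(Nc2ccnc(Nc3ccc(NS(=O)(=O)c4ccc(C)cc4)cc3)n2)cc1` differs from compound 2 in one place: methyl in place of trifluoromethyl on an aromatic carbon. Among the measured compounds shown here, only one measured step bears on this position, a 4.0-fold higher number from compound 1 to compound 2 (0.60 log units; beyond the scatter), where exchanging methoxy for trifluoromethyl raised the number modestly. For the measured compounds named here, no measured step exchanges trifluoromethyl for methyl anywhere, so the direction rests on that single comparison. The expectation is that taking away trifluoromethyl lowers the number again, by a step beyond the scatter but smaller than the one already seen. The step expected here is a 2.3-fold lower number from compound 2 to compound 3 (0.36 log units; beyond the scatter). Compound 3 is therefore estimated at 12000 nM in this assay, with a range from 5000 nM to 30000 nM.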

Compound 3, half-maximal inhibitory concentration: 21200 nM
For compound 3 the middle estimate is 1.8-fold (0.25 log units) below the measured one, and the stated range covers the measured number.
By their numbers in this assay, from the lowest: compound 1; then compounds 3 and 2 (each within the scatter of the next).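

In this assay, a 1.3-fold lower number from compound 2 to compound 3 (0.11 log units; within the scatter), so exchanging trifluoromethyl for methyl on this aromatic carbon, with its three fluorine atoms leaving, gives no change that can be told from the scatter. The earlier pair showed only that methoxy and trifluoromethyl part ways here; a 3.1-fold higher number from compound 1 to compound 3 (0.49 log units; beyond the scatter) now shows that methyl parts from methoxy as well, so the gap is not tied to trifluoromethyl, and among these three groups compound 1 alone stands apart, with a lower number than compound 2 and compound 3. Nothing on hand offers an explanation for why methoxy stands apart at this position.

Open, on these data alone, is whether that separation follows the oxygen of methoxy or belongs to methoxy alone: a hydroxyl, an amine or a longer ether chain such as ethoxy on the same aromatic carbon could fall with compound 1 or with compound 2 and compound 3. Also open, as far as these compounds go, is whether the same order would hold with any change elsewhere on the shared core, since all three compounds vary in this one place only.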